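From a phenoxy ether to a hydroxycyclohexyl ether

This account rests on a few compounds, and the source may have more. Where it says the series, first, only, none or still open, it means among the compounds named here.

In an assay on HEK293 cells for inhibition of N-acylethanolamine-hydrolyzing acid amidase (Rattus norvegicus), read by LC-MS, with a stated time of 30 min (a lower number here means a stronger inhibitor, a higher number a weaker inhibitor), compound 3 `O=C1OCCN1C(=O)c1ccc(Oc2ccccc2)cc1` gives 680 nM. Among the two compounds with a numerical result, compound 3 carries the highest number; the nearest is compound 1 `O=C(CCCCCc1ccc(O)c(F)c1)N1CCOC1=O`, which in this assay gives 160 nM, and that gap lies beyond the usual scatter. Compound 2 `O=C(CCCCCc1cccc(CO)c1)N1CCOC1=O` reaches only a limit of the assay, > 20000 nM, as described by the limit of > 20000 nM in this assay, at which 1 of the 3 values shown sits. Among the measured compounds shown here, no two of the three measured compounds differ in just one place, so no single measured step can be traced across them.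

Compound 4 `O=C1OCCN1C(=O)c1ccc(OC2CCC(O)CC2)cc1` has not yet been measured. It differs from compound 3 in one place: 4-hydroxycyclohexyl in place of phenyl on an oxygen on an aromatic ring. For the measured compounds named here, with no measured step of this kind to lean on, the step from compound 3 to compound 4 is expected to be a modest weakening, a 2.2-fold higher number from compound 3 to compound 4 (0.34 log units; beyond the scatter), though a change within the scatter cannot be ruled out. Compound 4 is therefore estimated at 1500 nM, with a range from 400 nM to 6000 nM.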

Compound 4, half-maximal inhibitory concentration: 210 nM
For compound 4 the middle estimate is 7.1-fold (0.85 log units) above the measured one; measured number below the stated range.
By their numbers in this assay, from the lowest: compounds 1 and 4 (each within the scatter of the next); then compound 3. At a limit, above all of these: compound 2.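

In this assay, among the compounds shown here, the swap of phenyl for 4-hydroxycyclohexyl gives a 3.2-fold lower number from compound 3 to compound 4 (0.51 log units; beyond the scatter) and this is the first single change that can be read. It shows that an aromatic ring is not needed on this oxygen, since a non-aromatic ring of carbon carrying a hydroxyl group is tolerated here and does better than phenyl. Nothing shown here accounts for the size or the direction of this step.

The compounds shown leave open whether the gain belongs to the hydroxyl group or to the non-aromatic ring, a question that a plain cyclohexyl group on the same oxygen would settle. They also leave open how an amine or a carboxylic acid would fare in place of that hydroxyl group.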